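This account rests on a few compounds, and the source may have more. Where it says the series, first, only, none or still open, it means among the compounds named here.

For the measured compounds named here, compound 1, `CC(=O)OCc1ccc2oc(=O)c(C(=O)Oc3cccc(Cl)c3)cc2c1`, is one of two compounds so far measured in a functional assay on HT-1080 cells (Homo sapiens), read by transwell migration, with a stated time of 24 h, tested at 10 uM (on this read-out higher numbers stand for a weaker effect at the one concentration tested and lower numbers for a stronger effect), and in this assay compound 1 gives 6.17%. Compound 2, `CC(=O)OCc1ccc2oc(=O)c(C(=O)Sc3cccc(Cl)c3)cc2c1`, carries (3-chlorophenyl)sulfanyl in place of 3-chlorophenoxy on the carbonyl carbon; in this assay compound 2 gives 61.9%. Among the two numbers compound 1 therefore stands lowest, the single step of a number 55.7 percentage points higher from compound 1 to compound 2 (beyond the scatter) being large and beyond the scatter.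

Compound 3, `CC(=O)OCc1ccc2oc(=O)c(C(=O)Nc3cccc(Cl)c3)cc2c1`, has not yet been measured. It differs from compound 1 by (3-chlorophenyl)amino in place of 3-chlorophenoxy on a carbonyl carbon. Going by the values given here, the only measured step that bears on this change is a number 55.7 percentage points higher from compound 1 to compound 2 (beyond the scatter), which also exchanged the group on the same carbonyl carbon and raised the number strongly. Among the compounds with values here, the group entering compound 3 is not the one that entered compound 2, so the size of that step carries over only loosely; still, a rise beyond the scatter, though smaller than for compound 2, is the more likely outcome. The estimate for compound 3 in this assay is 35%, with a range from 6% to 70%. The step that this estimate means is expected to be a number 28.8 percentage points higher from compound 1 to compound 3 (beyond the scatter).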

Compound 3, a percentage reported as activity, at one concentration (the size of the read-out at that concentration, not a potency): 42.8%
Estimate against measurement, compound 3: 7.8 percentage points below; the range from low to high includes it.
By their numbers in this assay, from the lowest: compound 1; then compound 3; then compound 2.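

In this assay, the exchange on the carbonyl carbon that first appeared with (3-chlorophenyl)sulfanyl is no isolated case: (3-chlorophenyl)amino in place of 3-chlorophenoxy gives a number 36.6 percentage points higher from compound 1 to compound 3 (beyond the scatter), so among these three compounds both replacements of 3-chlorophenoxy go the same way, and none goes against this. The two replacements are also distinct from each other, with a number 19.1 percentage points lower from compound 2 to compound 3 (beyond the scatter), which places (3-chlorophenyl)amino in an intermediate position and leaves compound 1 with the strongest effect at the one concentration tested. The count under the change shifts from a hydrogen-bond acceptor to a hydrogen-bond donor, but nothing available connects that difference, or any other feature of these groups, to the order of the three numbers.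

Going by these compounds, all three compounds keep the same chlorinated aryl group and the same core, so it remains open whether this order would hold with a plain phenyl or a methoxyphenyl group on the carbonyl carbon. A single concentration also leaves open how the three compare in potency, and how a carboxylic acid or a simple alkyl amine at this carbonyl carbon would behave.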